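Hydroxy to Ethylurea on a Shared Fused Core

The compounds below may be only part of what the source reports. "The series", "measured", "known", "first", "only" and "open" are said of these compounds alone.

Compound 1 `O=C(Nc1ccccc1)Nc1[nH]nc2nnc(-c3ccccc3)c(-c3ccccc3)c12`: > 100000 nM
Compound 2 `Oc1[nH]nc2nnc(-c3ccccc3)c(-c3ccccc3)c12`: > 100000 nM

In a functional assay on PC-3 cells (Homo sapiens) for cytotoxicity (on this read-out lower numbers stand for stronger inhibition and higher numbers for weaker inhibition), compound 1 gives > 100000 nM, which is a limit of the assay and not a number. In the same assay compound 2 gives > 100000 nM, again a limit. The step that the two limits leave unreadable from compound 1 to compound 2 is therefore unreadable, because the limit of > 100000 nM in this assay, at which 2 of the 2 values shown sit, is where both values sit. Among the measured compounds shown here, compound 2 thus stands at that limit, and the one further value shown is also a limit, so no ranking among the measured compounds is possible.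

Compound 3 `CCNC(=O)Nc1[nH]nc2nnc(-c3ccccc3)c(-c3ccccc3)c12` differs from compound 2 in one place: (ethylcarbamoyl)amino in place of hydroxy on an aromatic carbon. For the measured compounds named here, no measured step bears on this change, since the only measured step, a step that the two limits leave unreadable from compound 1 to compound 2, has no readable size. With compound 2 at the limit, compound 3 is expected to give about 150000 nM, with a range from 30000 nM to 1000000 nM. The implied step that the limit leaves unreadable from compound 2 to compound 3 is expected to stay within the scatter, most likely as another limit.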

Compound 3, half-maximal inhibitory concentration: > 100000 nM
Compound 3: a limit, no number; the forecaster's own chance of this, stated with the estimate: 80%; the middle value lies beyond the limit too.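

No step can be read among compound 1, compound 2 and compound 3, because all of them sit at one limit: the limit of > 100000 nM in this assay, at which 3 of the 3 values shown sit.

The compounds shown leave open whether hydroxy, (ethylcarbamoyl)amino and (phenylcarbamoyl)amino differ at all in this assay, since none of them gives an actual number.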